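Biaryl arm in place of the dichlorostyryl group

This account rests on a few compounds, and the source may have more. Where it says the series, first, only, none or still open, it means among the compounds named here.

Compound 1 `COC(=O)/C=C/c1cccc(N(Cc2ccc(/C=C/c3c(Cl)cccc3Cl)cc2)C(=O)C2CCCCC2)c1` gives 151 nM in an assay on isolated protein with Bile acid receptor (Homo sapiens) as the target (on this read-out lower numbers stand for an effect already at smaller amounts and higher numbers for an effect only at larger amounts of compound), the second highest of the three numbers recorded. Compound 2 `COC(=O)/C=C/c1cccc(N(Cc2ccc(-c3cccc(OC)c3)cc2)C(=O)C(C)C)c1` gives 72.4 nM in this assay, a lower number than compound 1 and beyond the scatter, while compound 3 `COC(=O)/C=C/c1cccc(N(Cc2ccc(-c3cccc(Cl)c3)cc2)C(=O)NC(C)C)c1` gives 1410 nM, the highest of the three. Compound 4 `COC(=O)/C=C/c1cccc(N(Cc2ccc(-c3cccc(OC(F)(F)F)c3)cc2)C(=O)C2CCCCC2)c1` differs from compound 1 by 3-(trifluoromethoxy)phenyl in place of 2-(2,6-dichlorophenyl)ethenyl on an aromatic carbon. Going by the values given here, no measured pair isolates this change; compounds 2 and 3 also carry a biaryl arm, and their numbers lie on either side of compound 1. For compound 4 the expected step of a 1.3-fold lower number from compound 1 to compound 4 (0.10 log units; within the scatter) should stay within the scatter. The estimate for compound 4 is 120 nM, with a range from 35 nM to 450 nM.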

Compound 4, half-maximal effective concentration: 417 nM
The estimate for compound 4 lay 3.5-fold (0.54 log units) below the measured number; measured number inside the range.
By their numbers in this assay, from the lowest: compound 2; then compound 1; then compound 4; then compound 3.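

With the rest of compound 1 unchanged, this assay gives a 2.8-fold higher number from compound 1 to compound 4 (0.44 log units; beyond the scatter), a modest step beyond the scatter. Going by these compounds alone, this is the first reading of this aromatic position alone, since compounds 2 and 3 also differ from compound 1 in the amide part, and here the biaryl arm does not match the 2-(2,6-dichlorophenyl)ethenyl arm. No data at hand explain the step.

Open, on these data alone, is whether the step follows from losing the ethenyl link or from the change of ring substituents. Also open, as far as these compounds go, is how an amine on the terminal ring would compare with 3-(trifluoromethoxy)phenyl.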